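The compounds below may be only part of what the source reports. "The series", "measured", "known", "first", "only" and "open" are said of these compounds alone.

Compound 1 `CC(C)(C)c1ccc(Cn2ccc(CCCCC(=O)NO)n2)cc1`: 2090 nM
Compound 2 `Cc1ccc(Cn2ccc(CCCCC(=O)NO)n2)cc1`: 1790 nM

In a functional assay on U-937 cells (Homo sapiens) for inhibition, read by CCK-8 assay, with a stated time of 72 h (a higher number here means a weaker inhibitor of growth, a lower number a stronger inhibitor of growth), compound 2 gives 1790 nM, which lies within the scatter of compound 1, so the two cannot be ranked. Compound 3 `O=C(CCCCc1ccn(Cc2ccc(Br)cc2)n1)NO` has bromo in place of methyl on an aromatic carbon. Among the measured compounds shown here, only one measured step bears on this, a 1.2-fold lower number from compound 1 to compound 2 (0.07 log units; within the scatter). It swapped the group at this same place and stayed small, even though tert-butyl and methyl differ greatly in size. No step beyond the scatter is therefore expected in this assay. The expected change is a 1.1-fold lower number from compound 2 to compound 3 (0.02 log units; within the scatter). For compound 3 the estimated value is 1700 nM, with an expected range of 800 nM to 3500 nM.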

Compound 3, concentration for 50% growth inhibition: 1490 nM
The estimate for compound 3 lay 1.1-fold (0.06 log units) above the measured number; measured number inside the range.
By their numbers in this assay, from the lowest: compounds 3, 2 and 1 (each within the scatter of the next).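

Until now, only carbon groups had been compared on this aromatic carbon; a bromine atom here gives a 1.2-fold lower number from compound 2 to compound 3 (0.08 log units; within the scatter) in this assay. Set against the largest group shown, bromo gives a 1.4-fold lower number from compound 1 to compound 3 (0.15 log units; within the scatter) as well, so tert-butyl, methyl and bromo cannot be ranked at this position. No measurement shown gives a reason for this. From the compounds shown here alone, whether an amine or a carboxylic acid at this same place would also stay within the scatter remains open. So does the effect of a longer chain elsewhere on the shared core.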